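The source may report more compounds than this note shows. Statements on the series, on what has been measured and on what is new or still open speak of the compounds shown alone.

Working notes on the series. In a functional assay on DU-145 cells (Homo sapiens) for inhibition, read by trypan blue exclusion, with a stated time of 96 h (a lower number here means a stronger inhibitor of growth, a higher number a weaker inhibitor of growth), compound 1 `O=C(O)c1ccc(C(=O)/C(=C\c2ccc(F)c([N+](=O)[O-])c2)SCc2ccc(Cl)cc2)cc1` gives 50000 nM, compound 2 `COc1ccc(/C=C(/SCc2ccc(F)cc2)C(=O)c2ccc(Br)cc2)cc1O` gives 1000 nM and compound 3 `O=C(O)c1ccc(C(=O)/C(=C\c2ccc(F)c([N+](=O)[O-])c2)SCc2ccc(F)cc2)cc1` gives 1000 nM. Compound 3 stands level with compound 2 to the digits given, the two together the lowest numbers of the three, while compound 1 is furthest off: a 50-fold lower number from compound 1 to compound 3 (1.70 log units; beyond the scatter). Compound 4 `COc1ccc(/C=C(/SCc2ccc(F)cc2)C(=O)c2ccc(C(=O)O)cc2)cc1O` comes next: 3-hydroxy-4-methoxyphenyl in place of 4-fluoro-3-nitrophenyl on a double-bonded chain carbon bound to a double-bonded chain carbon. Going by the values given here, no measured step bears directly on this change, the one available step concerning the other end of the shared core. Compound 2 already carries 3-hydroxy-4-methoxyphenyl with the same thioether and sits level with compound 3, so in this assay no step beyond the scatter is expected. The expected step is no change at the digits printed from compound 3 to compound 4 (within the scatter). Compound 4 is estimated at 1000 nM, between 300 nM and 3500 nM.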

Compound 4, concentration for 50% growth inhibition: 10000 nM
The estimate for compound 4 lay 10-fold (1.00 log units) below the measured number; the measured number lies above the stated range.
By their numbers in this assay, from the lowest: compounds 2 and 3 (each within the scatter of the next); then compound 4; then compound 1.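

In this assay, going by these compounds alone, 3-hydroxy-4-methoxyphenyl in place of 4-fluoro-3-nitrophenyl on a double-bonded chain carbon bound to a double-bonded chain carbon is the first change read at this position, and it is not neutral (a 10-fold higher number from compound 3 to compound 4 (1.00 log units; beyond the scatter)). With 3-hydroxy-4-methoxyphenyl held fixed, carboxy in place of bromo on an aromatic carbon also costs growth inhibition (a 10-fold higher number from compound 2 to compound 4 (1.00 log units; beyond the scatter)). Nothing available accounts for either step. On these data alone, whether the 3-hydroxy-4-methoxyphenyl step would be the same size with bromo in place of carboxy remains open. So does the reading for a phenyl carrying an amine at this position.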